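The compounds below may be only part of what the source reports. "The series", "measured", "known", "first", "only" and "open" are said of these compounds alone.

Of the compounds shown here, three sharing one core have been measured in a functional assay on SQ20B cells (Homo sapiens) for cytotoxicity, read by MTT assay, with a stated time of 72 h; on this read-out lower numbers stand for stronger inhibition and higher numbers for weaker inhibition. Compound 1 `CCN(CC)Cc1c(O)ccc2oc(Cc3ccccc3)cc12` gives 12000 nM in this assay. Compound 2 `CN(Cc1c(O)ccc2oc(Cc3ccccc3)cc12)C1CCCCC1` gives 12000 nM. Compound 3 `Oc1ccc2oc(Cc3ccccc3)cc2c1CN1CCC(O)CC1` gives 13000 nM. Compound 3 thus returns the largest of the three numbers, yet it is not separated from either neighbour: a 1.1-fold higher number from compound 1 to compound 3 (0.03 log units; within the scatter) and a 1.1-fold higher number from compound 2 to compound 3 (0.03 log units; within the scatter), and likewise no change at the digits printed from compound 1 to compound 2 (within the scatter). On the numbers shown, compound 3 stands level with the other two.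

Compound 4 `NC(=O)C1CCN(Cc2c(O)ccc3oc(Cc4ccccc4)cc23)CC1` is the next step from compound 3, with carbamoyl in place of hydroxy on a saturated ring carbon. Going by the values given here, no measured step alters a substituent on the piperidine ring; the steps that exist swap the whole amino group on the saturated chain carbon bound to an aromatic carbon, and every one of them stays within the scatter. Those steps bear only loosely on this change, but they give no sign that the amine part moves this read-out, so no shift beyond the scatter is expected here, no change at the digits printed from compound 3 to compound 4 (within the scatter). Compound 4 is therefore estimated at 13000 nM in this assay, with a likely range of 6000 nM to 28000 nM.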

Compound 4, half-maximal inhibitory concentration: 85000 nM
Beside the measured number, compound 4's estimate is 6.5-fold (0.82 log units) below it; the measured number lies above the stated range.
By their numbers in this assay, from the lowest: compounds 1, 2 and 3 (each within the scatter of the next); then compound 4.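

In this assay this ring carbon, three ring bonds from the ring nitrogen, proves sensitive where exchanges of the whole amino group had shown nothing: carbamoyl in place of hydroxy gives a 6.5-fold higher number from compound 3 to compound 4 (0.82 log units; beyond the scatter) and is the first step in the series beyond the scatter. The amine comparisons point the same way, since 4-carbamoylpiperidin-1-yl gives a 7.1-fold higher number from compound 2 to compound 4 (0.85 log units; beyond the scatter) in place of cyclohexyl(methyl)amino and a 7.1-fold higher number from compound 1 to compound 4 (0.85 log units; beyond the scatter) in place of diethylamino, so the level standing of the three earlier amines does not extend to this one. No available measurement accounts for the weakening.

As far as these compounds go, whether it belongs to carbamoyl itself remains open. A carboxylic acid, a methyl ester or an aminomethyl group on the same ring carbon would test how specific it is.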